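Methyl on the phenyl ring of compound 1

The compounds below may be only part of what the source reports. "The series", "measured", "known", "first", "only" and "open" are said of these compounds alone.

Measured compounds:
compound 1 `O=C1N/C(=N/c2ccccc2)S/C1=C\c1ccccn1`: 26.2%
compound 2 `O=C1N/C(=N\Nc2ccccc2)S/C1=C\c1ccccn1`: 39.7%
compound 3 `O=C1N/C(=N/c2ccc([N+](=O)[O-])cc2Cl)S/C1=C\c1ccccn1`: 39.7%

Of the compounds shown here, three sharing one core have been tested in a functional assay on the whole organism (strain Wistar) for inhibition, with Rattus norvegicus as the target, read by paw edema, with stated times of 30 min and 120 min, at a dose of 10 mg/kg by the oral route; a higher number here means more inhibition at the dose given (going by the name of the read-out), a lower number less inhibition. Compound 1 `O=C1N/C(=N/c2ccccc2)S/C1=C\c1ccccn1` gives 26.2%, the lowest of the three numbers. Compound 2 `O=C1N/C(=N\Nc2ccccc2)S/C1=C\c1ccccn1` gives 39.7% and compound 3 `O=C1N/C(=N/c2ccc([N+](=O)[O-])cc2Cl)S/C1=C\c1ccccn1` gives 39.7%; each of these stands above compound 1 by a margin beyond the usual scatter, while the two of them lie at the same number.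

Compound 4 `Cc1ccccc1/N=C1/NC(=O)/C(=C/c2ccccn2)S1` has not been measured. It differs from compound 1 in one place: methyl in place of hydrogen on an aromatic carbon. The change is methyl in place of hydrogen on an aromatic carbon of the phenyl ring, so that phenyl becomes 2-methylphenyl.

For the measured compounds named here, no step between two measured compounds matches this change, so there is nothing in the data to set its direction or size. The expected step is a number 3.8 percentage points higher from compound 1 to compound 4 (within the scatter), a change not beyond the scatter. Compound 4 is therefore estimated at 30%, with a range from 15% to 45%.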

Compound 4, a percentage reported as inhibition, in the whole organism at one dose (the size of the read-out at that dose, not a potency): 30.4%
For compound 4 the middle estimate is 0.4 percentage points below the measured one; low and high end bracket the measured number.
By their numbers in this assay, from the lowest: compounds 1, 4, 2 and 3 (each within the scatter of the next, the first and the last beyond it).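

In this assay the exchange of hydrogen for methyl on an aromatic carbon ortho to a large group, turning phenyl into 2-methylphenyl, gives a number 4.2 percentage points higher from compound 1 to compound 4 (within the scatter) and so leaves compound 4 not separable from compound 1 at the dose given. For the compounds shown here, the earlier compounds offered no step between two compounds differing in one place, so this is the first direct reading at the phenyl ring: at this place on the ring, a single methyl produces no difference that stands clear of the usual scatter of the read-out. The data on hand offer no measurement that would account for the size of this step.

From the compounds shown here alone, whether a longer chain such as ethyl, or a different group such as methoxy, an amine or a carboxylic acid, would give a step beyond the scatter at this same place remains open. Also open, going by these compounds, is whether methyl on another carbon of the phenyl ring would read the same way as it does in compound 4.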